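Benzyl substituent swap in the bombesin receptor subtype-3 series

The source may report more compounds than this note shows. Statements on the series, on what has been measured and on what is new or still open speak of the compounds shown alone.

Working notes on the series. In an in vitro functional assay on cells for agonist activity at Bombesin receptor subtype-3 (Homo sapiens), read by luminescence and calcium flux (a lower number here means that less compound is needed, a higher number that more compound is needed for the effect), compound 2 `O=C(O)c1ccccc1-c1ccc(CCc2ncc(Cc3ccccc3Cl)[nH]2)cc1` gives 292 nM, the higher of the two numbers in hand. Compound 3 `CCC(C)(C)Cc1c[nH]c(CCc2ccc(-c3ccccc3C(=O)O)cc2)n1` gives 25 nM in this assay, a lower value that lies beyond the scatter. For compound 1 `CCCCc1cnc(Cc2ccc(-c3ccccc3C(=O)O)cc2)[nH]1` the assay reports only a limit, > 10000 nM; (the limit of > 10000 nM in this assay, at which 1 of the 3 values shown sits). The untested compound 4 `Cc1ccc(Cc2cnc(CCc3ccc(-c4ccccc4C(=O)O)cc3)[nH]2)cc1` differs from compound 2 at a single place: 4-methylphenyl in place of 2-chlorophenyl on a saturated chain carbon bound to an aromatic carbon. Within the data shown here, no measured pair in this set isolates that change, so the data do not fix its direction. The step expected in this assay from compound 2 to compound 4 is a 1.2-fold higher number from compound 2 to compound 4 (0.08 log units; within the scatter), small and likely within the scatter. Compound 4 is estimated at 350 nM in this assay, with a range from 100 nM to 1200 nM.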

Compound 4, half-maximal effective concentration: 2660 nM
Estimate against measurement, compound 4: 7.6-fold (0.88 log units) below; measured number outside the range, above it.
By their numbers in this assay, from the lowest: compound 3; then compound 2; then compound 4. At a limit, above all of these: compound 1.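

In this assay, this position on a saturated chain carbon bound to an aromatic carbon proves sensitive to the aryl group it carries, with a 9.1-fold higher number from compound 2 to compound 4 (0.96 log units; beyond the scatter). The change from 2-chlorophenyl to 4-methylphenyl keeps the heavy-atom count and the ring type and adds no hydrogen-bond donors or acceptors, so those counts do not track the step. No property measured for these compounds bears on this step.

Still open, on these data alone, is whether the step follows the exchange of chloro for methyl or the change of substitution from 2 to 4. Either 2-methylphenyl or 4-chlorophenyl at this carbon would separate the two.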